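The source may report more compounds than this note shows. Statements on the series, on what has been measured and on what is new or still open speak of the compounds shown alone.

Working notes on the series. Within the data shown here, in an ADME assay on L02 cells (Homo sapiens) for inhibition, read by CCK-8 assay, with a stated time of 48 h (on this read-out lower numbers stand for stronger inhibition of growth and higher numbers for weaker inhibition of growth), compound 1 `CCN1CCN(c2ccc(Nc3ncc(Cl)c(Nc4ccccc4C)n3)cc2)CC1` gives 970 nM and compound 2 `Cc1ccccc1Nc1nc(Nc2ccc(N3CCN(C(=O)OC(C)(C)C)CC3)cc2)ncc1Cl` gives 1750 nM; the one step with numbers on both sides, a 1.8-fold higher number from compound 1 to compound 2 (0.26 log units; within the scatter), concerns an amine nitrogen in a ring and does not touch the position altered here. Compound 3 `Cc1ccc(CNc2nc(Nc3ccc(N4CCN(C)CC4)cn3)ncc2Cl)cc1` stands only at a limit of this assay, > 100000 nM, which is where one of the three values sits (the limit of > 100000 nM in this assay, at which 1 of the 3 values shown sits). Compound 4 `COc1cccc(Nc2nc(Nc3ccc(N4CCN(C)CC4)cn3)ncc2Cl)c1` differs from compound 3 by 3-methoxyphenyl in place of 4-methylbenzyl on a nitrogen on an aromatic ring. Among the measured compounds shown here, no measured step bears on this change, so no size can be taken from the measured pairs. The expected step from compound 3 to compound 4 is an at least 6.6-fold lower number from compound 3 to compound 4 (0.82 log units; beyond the scatter), set wide and leaning toward a lower number. For compound 4 the estimate in this assay is 15000 nM, with a range from 2000 nM to 100000 nM.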

Compound 4, concentration for 50% growth inhibition: 3470 nM
Beside the measured number, compound 4's estimate is 4.3-fold (0.64 log units) above it, and the stated range covers the measured number.
By their numbers in this assay, from the lowest: compounds 1, 2 and 4 (each within the scatter of the next, the first and the last beyond it). At a limit, above all of these: compound 3.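

In this assay the group on this nitrogen on an aromatic ring proves to matter: 3-methoxyphenyl in place of 4-methylbenzyl gives an at least 28-fold lower number from compound 3 to compound 4 (1.45 log units; beyond the scatter). Among these compounds, the earlier step, on an amine nitrogen in a ring, stayed within the scatter, so this is the first change with a step beyond it. The step is a bound and not a size: the limit of > 100000 nM in this assay, at which 1 of the 4 values shown sits.

On these data alone, it remains open whether the step follows the methoxy group or the loss of the benzyl linkage; a 3-methoxybenzyl or an unsubstituted phenyl on this nitrogen would separate the two.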